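Pyrrolidin-1-yl for diethylamino on a carbonyl carbon

The compounds below may be only part of what the source reports. "The series", "measured", "known", "first", "only" and "open" are said of these compounds alone.

Measured in an ADME assay on HeLa cells (Homo sapiens) for cytotoxicity, read by MTT assay; on this read-out higher numbers stand for weaker inhibition and lower numbers for stronger inhibition:
compound 1 `COc1ccc(C[C@H]2COC(=O)[C@@H]2Cc2ccc(OCc3cn(-c4ccc(Br)cc4)nn3)c(OC)c2)cc1OC`: 128000 nM
compound 2 `CCN(CC)C(=O)COc1ccc(C[C@H]2C(=O)OC[C@@H]2Cc2ccc(OC)c(OC)c2)cc1OC`: 188000 nM

Compound 2 stands at 188000 nM, within the scatter of compound 1. Compound 3 `COc1ccc(C[C@H]2COC(=O)[C@@H]2Cc2ccc(OCC(=O)N3CCCC3)c(OC)c2)cc1OC` carries pyrrolidin-1-yl in place of diethylamino on a carbonyl carbon. Among the measured compounds shown here, only one measured step bears on this, and it tests a different exchange: a 1.5-fold higher number from compound 1 to compound 2 (0.17 log units; within the scatter). That step stayed within the scatter, so no change beyond the scatter is expected in this assay. The expected step is a 1.2-fold lower number from compound 2 to compound 3 (0.07 log units; within the scatter). For compound 3 the estimate is 160000 nM, with an expected range of 80000 nM to 320000 nM.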

Compound 3, half-maximal inhibitory concentration: >= 600000 nM
Compound 3: no number, only a limit; the forecaster's own chance of this, stated with the estimate: 15%; at least 3.7-fold (0.57 log units) between middle value and limit.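

In this assay compound 3 gives no number, only a limit of the assay: the limit of >= 600000 nM in this assay, at which 1 of the 3 values shown sits. Closing diethylamino into pyrrolidin-1-yl on a carbonyl carbon, a change that leaves the heavy-atom count as it was, still gives an at least 3.1-fold higher number from compound 2 to compound 3 (0.50 log units; beyond the scatter), whereas the earlier step stayed within the scatter. Putting (pyrrolidin-1-yl)carbonyl in place of 1-(4-bromophenyl)-1H-1,2,3-triazol-4-yl gives an at least 4.6-fold higher number from compound 1 to compound 3 (0.67 log units; beyond the scatter). From the compounds shown here alone, how far the true number lies past the limit stays open. So does whether a piperidin-1-yl or morpholin-4-yl group on this carbonyl carbon would side with pyrrolidin-1-yl or with diethylamino.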